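The source may report more compounds than this note shows. Statements on the series, on what has been measured and on what is new or still open speak of the compounds shown alone.

In a functional assay on HCT-116 cells (Homo sapiens) for cytotoxicity, read by sulforhodamine B assay, with a stated time of 24 h (on this read-out lower numbers stand for stronger inhibition and higher numbers for weaker inhibition), three compounds sharing one core have been measured. Compound 1 `N#CCC(=O)N/N=C1\C(=O)Nc2ccc(S(=O)(=O)N3CCOCC3)cc21` gives 10300 nM, compound 2 `N=c1oc2ccccc2cc1C(=O)N/N=C1\C(=O)Nc2ccc(S(=O)(=O)N3CCOCC3)cc21` gives 6750 nM and compound 3 `O=C1Nc2ccc(S(=O)(=O)N3CCOCC3)cc2/C1=N/c1ccc(Br)cc1` gives 15300 nM. Compound 3 lies within the scatter of compound 1, while its number is higher than that of compound 2 by more than the scatter.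

The next compound, compound 4 `Cc1ccc(/N=C2\C(=O)Nc3ccc(S(=O)(=O)N4CCOCC4)cc32)cc1`, differs from compound 3 as follows: methyl in place of bromo on an aromatic carbon. This is methyl in place of bromo on an aromatic carbon, para to a large group.

Going by the values given here, no measured step varies this position directly. The nearest evidence is a 1.5-fold higher number from compound 1 to compound 3 (0.17 log units; within the scatter), which brings in the 4-bromophenyl group, and a 1.5-fold lower number from compound 1 to compound 2 (0.18 log units; within the scatter). Both stay within the scatter although each exchanges a whole group. A single-atom exchange is therefore expected to produce no change beyond the scatter in this assay.

The expected result is a 1.1-fold lower number from compound 3 to compound 4 (0.04 log units; within the scatter). For compound 4 the estimated value is 14000 nM, with an expected range of 7500 nM to 26000 nM.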

Compound 4, half-maximal inhibitory concentration: 18900 nM
Beside the measured number, compound 4's estimate is 1.4-fold (0.13 log units) below it; the range from low to high includes it.
By their numbers in this assay, from the lowest: compounds 2, 1, 3 and 4 (each within the scatter of the next, the first and the last beyond it).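

Methyl in place of bromo, on an aromatic carbon para to a large group, is the first direct variation at this position and, in this assay, gives a step within the scatter (a 1.2-fold higher number from compound 3 to compound 4 (0.09 log units; within the scatter)). Set against the acyl group of compound 1, the 4-methylphenyl group also stays within the scatter (a 1.8-fold higher number from compound 1 to compound 4 (0.26 log units; within the scatter)), so neither 4-bromophenyl nor 4-methylphenyl separates from compound 1 on this read-out. No measurement shown here accounts for the close agreement between the bromo and methyl compounds.

As far as these compounds go, whether an amine or a carboxylic acid at this same place would move the number beyond the scatter remains open. From the compounds shown here alone, a longer chain, such as butyl, is equally open, so the tolerance seen here rests on only bromo and methyl.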